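The source may hold more compounds than are shown below. What is called first, only, known or untested is meant among the compounds shown, and "the series" means these compounds.

Of the compounds shown here, two have numbers so far in a physicochemical assay for lipophilicity; a lower number here means a more polar compound, a higher number a more lipophilic compound: compound 1 (`CCOC(=O)/C=C(C)/C=C/CC(C)CCCC(C)(C)OCC`) gives 6.08, and compound 2 (`CCOC(=O)/C=C(C)/C=C/CC(C)CCC=C(C)C`) gives 6.19. Among the compounds with values here, compound 2 therefore stands within the scatter of compound 1, the only other compound on this scale, and the pair gives no reliable order.

Next is compound 3 (`C=C(C)CCCC(C)C/C=C/C(C)=C/C(=O)OCC`), which has the same atoms as compound 2, joined differently: 2-methylprop-2-en-1-yl in place of 2-methylprop-1-en-1-yl on a saturated chain carbon, four bonds along the chain from a double-bonded chain carbon. In words, 2-methylprop-2-en-1-yl stands in place of 2-methylprop-1-en-1-yl on a saturated chain carbon, four bonds along the chain from a double-bonded chain carbon.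

Within the data shown here, only one measured step bears on this place: a number 0.11 log units higher from compound 1 to compound 2 (within the scatter). Among the measured compounds shown here, that step concerns a different exchange, between 2-ethoxy-2-methylpropyl and 2-methylprop-1-en-1-yl, and no measured pair tests the present change directly. No shift beyond the scatter is therefore expected in this assay, and the data support no firm direction. The expected change is a number 0.04 log units lower from compound 2 to compound 3 (within the scatter). For compound 3, the estimated value is 6.15, with an expected range from 5.8 to 6.5.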

Compound 3, partition coefficient: 6.19
For compound 3 the middle estimate is 0.04 log units below the measured one; low and high end bracket the measured number.
By their numbers in this assay, from the lowest: compounds 1, 2 and 3 (each within the scatter of the next).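

In this assay, within the data shown here, 2-methylprop-2-en-1-yl in place of 2-methylprop-1-en-1-yl on a saturated chain carbon, four bonds along the chain from a double-bonded chain carbon, gives no change at the digits printed from compound 2 to compound 3 (within the scatter); this is the first measured pair at this place with the same atoms joined differently. With 1-methylethenyl in place of 1-ethoxy-1-methylethyl on a saturated chain carbon, five bonds along the chain from a double-bonded chain carbon, the series gives a number 0.11 log units higher from compound 1 to compound 3 (within the scatter), so compound 1, compound 2 and compound 3 all lie within the scatter of one another and no order can be drawn among them. No measured information accompanies these values that could account for them.

The compounds shown leave open whether this place would respond on this scale to a group of another kind, such as an amine, a carboxylic acid or a longer chain. As far as these compounds go, all three also share the same ethyl ester, so the effect of a change at that end of the molecule remains unknown.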